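Methoxy in place of hydroxy on the chlorophenyl ring

The source may hold more compounds than are shown below. What is called first, only, known or untested is meant among the compounds shown, and "the series" means these compounds.

Measured so far:
compound 1, `O=C(Nc1cccc(-n2cc(-c3ccncc3)c(-c3cc(O)cc(Cl)c3)n2)c1)Nc1ccc(Cl)c(Cl)c1`: 98%
compound 2, `COc1cc(Cl)cc(-c2nn(-c3cccc(NC(=O)Nc4cc(C(F)(F)F)cc(C(F)(F)F)c4)c3)cc2-c2ccncc2)c1`: 97%

In a functional assay on Hs-578T cells (Homo sapiens) for inhibition, read by sulforhodamine B assay, with a stated time of 48 h, tested at 0.01 uM (a higher number here means a weaker effect of the compound at the concentration tested, a lower number a stronger effect), compound 1 gives 98%. Compound 2 gives 97% in this assay. The two numbers lie within the scatter of each other, so compound 1 is not set apart from compound 2; both show hardly any effect at the concentration tested. For the measured compounds named here, no step between compounds that differ in a single place has been measured, so nothing is yet known about how any one change moves the read-out.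

Compound 3, `COc1cc(Cl)cc(-c2nn(-c3cccc(NC(=O)Nc4ccc(Cl)c(Cl)c4)c3)cc2-c2ccncc2)c1`, is the next compound for this assay. Compared with compound 1 the change is methyl in place of hydrogen on an oxygen on an aromatic ring. Compound 2 already carries the 3-chloro-5-methoxyphenyl group and gives a read-out close to compound 1, and both measured values sit near the top of the scale, so the expected step of a number 1 percentage points lower from compound 1 to compound 3 (within the scatter) is none beyond the scatter. For compound 3 in this assay the estimate is 97%, with a range from 88% to 104%.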

Compound 3, a percentage reported as activity, at one concentration (the size of the read-out at that concentration, not a potency): 93%
Estimate against measurement, compound 3: 4 percentage points above; measured number inside the range.
By their numbers in this assay, from the lowest: compounds 3, 2 and 1 (each within the scatter of the next).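

In this assay, for the compounds shown here, methyl in place of hydrogen on an oxygen on an aromatic ring gives a number 5 percentage points lower from compound 1 to compound 3 (within the scatter), the first step that isolates a change in one place. At this position, hydroxy and methoxy on the chlorophenyl ring therefore cannot be told apart in this read-out, and compound 3, at 93%, still shows hardly any effect at the concentration tested. No information is available that bears on the reason for this result.

As far as these compounds go, it remains open whether an ethoxy group or a longer chain on this oxygen, or an amine in place of the hydroxy, would move the read-out beyond the scatter. Because the read-out gives the size of the effect at one concentration and not a potency, it also remains open whether hydroxy and methoxy would separate at higher concentrations, where the effect of these compounds would be larger.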